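A few compounds are considered here, and "the series" means these few. Any claim that something is new, unique, unknown or untested is made for them only; others in the source may bear on it.

Working notes on the series.

Compound 1 `CC(C)C[C@H](NC(=O)CSc1cc(NS(=O)(=O)c2ccccc2)c2ccccc2c1O)B(O)O` is the reference point. In a functional assay on MCF7 cells (Homo sapiens) for antiproliferative activity, read by sulforhodamine B assay, with a stated time of 72 h (a lower number here means a stronger inhibitor, a higher number a weaker inhibitor), compound 1 gives 4160 nM. Compound 2 `CC(C)C[C@H](NC(=O)CSc1cc(NS(=O)(=O)c2ccc(Cl)cc2)c2ccccc2c1O)B(O)O` differs from compound 1 by chloro in place of hydrogen on an aromatic carbon, and in this assay compound 2 gives 10400 nM; the step is a 2.5-fold higher number from compound 1 to compound 2 (0.40 log units; beyond the scatter). Compound 3 `CC(C)C[C@H](NC(=O)CCSc1cc(NS(=O)(=O)c2ccccc2)c2ccccc2c1O)B(O)O` is built on a second core; how that core differs from the core of compound 1 is not broken down here. In this assay compound 3 gives 7460 nM, a number that sits within the scatter of both compound 1 and compound 2, so no order among these three can be read from it.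

Compound 4 `CC(C)C[C@H](NC(=O)CCSc1cc(NS(=O)(=O)c2ccc(Cl)cc2)c2ccccc2c1O)B(O)O` has not been measured. It differs from compound 3 by chloro in place of hydrogen on an aromatic carbon, the same change as that from compound 1 to compound 2, at the same place: on an aromatic carbon of a six-membered aromatic ring of carbon only, para to a large group. Among the compounds with values here, only this one measured pair shows the change.

The expectation for compound 4 rests on that pair: because a 2.5-fold higher number from compound 1 to compound 2 (0.40 log units; beyond the scatter) lies beyond the scatter, the step of a 2.3-fold higher number from compound 3 to compound 4 (0.36 log units; beyond the scatter) is expected to be of a comparable size and in the same direction. Compound 4 is accordingly estimated at 17000 nM. For compound 4 the expected range runs from 8000 nM to 40000 nM; a single supporting pair is thin evidence, and the range is kept wide to reflect that.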

Compound 4, half-maximal inhibitory concentration: 6910 nM
Beside the measured number, compound 4's estimate is 2.5-fold (0.39 log units) above it; measured number below the stated range.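

In this assay the chloro change does not carry over unchanged from the core of compound 1 to the core of compound 3, since the two steps differ: the same change on two cores in this assay, a 2.5-fold higher number (0.40 log units; beyond the scatter) from compound 1 to compound 2 and a 1.1-fold lower number (0.03 log units; within the scatter) from compound 3 to compound 4, 2.7-fold (0.43 log units) apart, beyond the scatter of two such steps. On the second core the step reads a 1.1-fold lower number from compound 3 to compound 4 (0.03 log units; within the scatter), so 4-chlorophenyl in place of phenyl gives no readable shift there, and the step that compares the two chloro compounds across the cores, a 1.5-fold lower number from compound 2 to compound 4 (0.18 log units; within the scatter), also shows no separation. With one pair on each core, this shows that the size of the step depends on the core within these four compounds, but it does not show why, nor how the change would behave on any other core or in any other assay.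

The compounds shown leave open whether another group at the same place on the aromatic ring, such as fluoro, methoxy or trifluoromethyl, would follow the step seen on the core of compound 1 or the one seen on the core of compound 3. From the compounds shown here alone, a longer chain on the sulfur also stays open, and with it whether the step stays as flat as on the core of compound 3.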